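Acyl-to-urea change on the sulfonate ester series

The compounds below may be only part of what the source reports. "The series", "measured", "known", "first", "only" and "open" are said of these compounds alone.

Measured so far in a functional assay on HT-29 cells (Homo sapiens) for antiproliferative activity, read by sulforhodamine B assay, with a stated time of 48 h; a higher number here means a weaker inhibitor, a lower number a stronger inhibitor:
compound 1 `CCCCCC(=O)Nc1ccc(S(=O)(=O)Oc2ccccc2I)cc1` gives 13000 nM
compound 2 `CC(C)(C)C(=O)Nc1ccc(S(=O)(=O)Oc2ccccc2I)cc1` gives 9500 nM
compound 3 `O=C(CCCl)Nc1ccc(S(=O)(=O)Oc2ccccc2I)cc1` gives 14000 nM

Compound 3 sits at the weak end of the three numbers, but only by margins inside the scatter: a 1.1-fold higher number from compound 1 to compound 3 (0.03 log units; within the scatter) and a 1.5-fold higher number from compound 2 to compound 3 (0.17 log units; within the scatter). The change from compound 1 to compound 2, a 1.4-fold lower number from compound 1 to compound 2 (0.14 log units; within the scatter), is likewise inside the scatter, so across the three measured compounds the group on the carbonyl carbon has not moved this assay beyond noise.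

Compound 4 `CCCNC(=O)Nc1ccc(S(=O)(=O)Oc2ccccc2I)cc1` takes this one step further: propylamino in place of 2-chloroethyl on a carbonyl carbon. Among the measured compounds shown here, the group that enters carries one hydrogen-bond donor and is joined through nitrogen rather than carbon, which none of the measured steps covers directly. The nearest guides are the three acyl exchanges, each within the scatter. For the measured compounds named here, no measured step therefore supports expecting a shift beyond the scatter in this assay, in either direction. The estimate for compound 4 is 12000 nM, between 4500 nM and 32000 nM, a step of a 1.2-fold lower number from compound 3 to compound 4 (0.07 log units; within the scatter), with the range widened for the untested nitrogen link.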

Compound 4, half-maximal inhibitory concentration: 6800 nM
Estimate against measurement, compound 4: 1.8-fold (0.25 log units) above; measured number inside the range.
By their numbers in this assay, from the lowest: compounds 4, 2, 1 and 3 (each within the scatter of the next, the first and the last beyond it).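

In this assay, among the compounds shown here, propylamino on the carbonyl carbon gives the only step so far that lies beyond the scatter (a 2.1-fold lower number from compound 3 to compound 4 (0.31 log units; beyond the scatter)), and that step is modest and holds against 2-chloroethyl alone. Against the other two groups the same exchange stays within the scatter (a 1.4-fold lower number from compound 2 to compound 4 (0.15 log units; within the scatter); a 1.9-fold lower number from compound 1 to compound 4 (0.28 log units; within the scatter)), so compound 4 is set apart from compound 3 but not from compound 1 or compound 2. Nothing available accounts for the step from compound 3 to compound 4.

As far as these compounds go, whether the step from compound 3 to compound 4 belongs to the nitrogen link or to the loss of 2-chloroethyl stays open. Compounds with dimethylamino, anilino or a longer chain on the nitrogen, such as hexylamino, would bear on how far this position can move the assay.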